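The source may report more compounds than this note shows. Statements on the series, on what has been measured and on what is new or still open speak of the compounds shown alone.

Measured compounds:
Compound 1 `CCCN(C)C(=O)c1ccc(-c2cc(-c3cc(OC)ccc3OC)no2)s1`: > 30000 nM
Compound 2 `COc1ccc(OC)c(-c2cc(-c3ccc(C(=O)N(C)C)s3)on2)c1`: > 30000 nM
Compound 3 `COc1ccc(CN(C)C(=O)c2ccc(-c3cc(-c4cc(OC)ccc4OC)no3)s2)cc1`: > 30000 nM

Compound 1 carries a propyl group on its amide nitrogen. In a functional assay on PC-3 cells (Homo sapiens) for cytotoxicity, read by XTT assay, with a stated time of 72 h (on this read-out higher numbers stand for weaker inhibition and lower numbers for stronger inhibition), compound 1 gives only a limit, > 30000 nM. Compound 2 differs by a step that the two limits leave unreadable from compound 1 to compound 2, and in this assay compound 2 again gives only a limit, > 30000 nM. Compound 3 is reached by a step that the two limits leave unreadable from compound 1 to compound 3, or from compound 2 by a step that the two limits leave unreadable from compound 2 to compound 3. In this assay compound 3 also gives only a limit, > 30000 nM. All three values therefore sit at the limit of > 30000 nM in this assay, at which 3 of the 3 values shown sit, so compound 3 stands level with the other two, and none of the three steps can be read in size or direction.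

Compound 4 `COc1ccc(OC)c(-c2cc(-c3ccc(C(=O)N4CCC(C(F)(F)F)CC4)s3)on2)c1` differs from compound 3 by 4-(trifluoromethyl)piperidin-1-yl in place of (4-methoxybenzyl)(methyl)amino on a carbonyl carbon. Within the data shown here, no measured step concerns this kind of exchange, and the three measured steps each end at the same limit, so they give no direction for the new change. The expected step in this assay is therefore a number no higher from compound 3 to compound 4 (the limit leaves the size open). Compound 4 is expected to give 30000 nM, most plausibly again as a limit, with a range from 8000 nM to 100000 nM.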

Compound 4, half-maximal inhibitory concentration: > 30000 nM
Compound 4 gave a limit, no number (the forecaster's own chance of this, stated with the estimate: 75%); the middle value sits exactly at the limit.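

In this assay compound 4 gives > 30000 nM, which is a limit and not a number. Its steps from compound 1, compound 2 and compound 3 therefore cannot be read: the limit of > 30000 nM in this assay, at which 4 of the 4 values shown sit.

These four compounds leave open whether any group on the carbonyl carbon changes the result in this assay, and by how much.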